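A 4-nitrophenyl swap on a compound without a number

The compounds below may be only part of what the source reports. "The series", "measured", "known", "first", "only" and "open" are said of these compounds alone.

Three compounds sharing one core have gone through an ADME assay on Vero cells (Chlorocebus sabaeus) for cytotoxicity, read by MTT assay; a lower number here means a stronger inhibitor, a higher number a weaker inhibitor. There compound 1 `C=CCOc1cc(OC)c(C(=O)/C=C/c2ccc(O)cc2)c(OCC=C)c1` gives 76400 nM and compound 2 `C=CCOc1cc(OC)c(C(=O)/C=C/c2ccc(C(F)(F)F)cc2)c(OCC=C)c1` gives 7200 nM. Between them lies an 11-fold lower number from compound 1 to compound 2 (1.03 log units; beyond the scatter), with trifluoromethyl in place of hydroxy on an aromatic carbon. Compound 3 `C=CCOc1cc(OC)c(C(=O)/C=C/c2ccc[nH]2)c(OCC=C)c1` offers no starting point, as its result reads "not determined" (no result reported).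

Compound 4 `C=CCOc1cc(OC)c(C(=O)/C=C/c2ccc([N+](=O)[O-])cc2)c(OCC=C)c1` differs from compound 3 as follows: 4-nitrophenyl in place of 1H-pyrrol-2-yl on a double-bonded chain carbon bound to a double-bonded chain carbon. With no number for compound 3, no size or direction can be expected for this step itself. Among the compounds with values here, the one measured step bears on it only indirectly, since it shows that the group carried on the aromatic ring can move the value well beyond the scatter. Like compound 2 at 7200 nM, compound 4 has no hydroxy group, so a value near that of compound 2 seems more likely than one near compound 1.

In this assay, compound 4 is expected at about 12000 nM, with an estimated range of 3500 nM to 40000 nM.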

Compound 4, half-maximal inhibitory concentration: 12600 nM
For compound 4 the middle estimate is 1.1-fold (0.02 log units) below the measured one; low and high end bracket the measured number.
By their numbers in this assay, from the lowest: compounds 2 and 4 (each within the scatter of the next); then compound 1.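

In this assay nitro in place of trifluoromethyl on an aromatic carbon gives a 1.8-fold higher number from compound 2 to compound 4 (0.24 log units; within the scatter) and so these two groups cannot be told apart here. Nitro in place of hydroxy gives a 6.1-fold lower number from compound 1 to compound 4 (0.78 log units; beyond the scatter) and this makes compound 4 the second compound, after compound 2, whose group on that carbon sets it clearly apart from the hydroxy compound 1. The step from compound 3 to compound 4 cannot be read, as compound 3 has no number, and no other data shown bear on what lies behind these differences.

From the compounds shown here alone, whether an amine or a carboxylic acid on the same aromatic carbon would give a value close to compound 1 or close to compounds 2 and 4 stays open. The same question holds for a plain hydrogen or a methoxy group there.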